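Trimming one chloro from the diaryl urea: compound 4

The source may report more compounds than this note shows. Statements on the series, on what has been measured and on what is new or still open speak of the compounds shown alone.

Measured compounds:
Compound 1, `O=C(Nc1ccccc1)Nc1cccc(CNc2nccnc2Cl)c1`: 16300 nM
Compound 2, `O=C(Nc1cccc(CNc2nccnc2Cl)c1)Nc1ccc(Cl)c(Cl)c1`: 4970 nM
Compound 3, `O=C(Nc1ccc(C(F)(F)F)cc1)Nc1cccc(CNc2nccnc2Cl)c1`: 6910 nM

Three ureas sharing one core have been measured in a functional assay on MGC-803 cells (Homo sapiens) for antiproliferative activity, read by MTT assay, with a stated time of 48 h; a lower number here means a stronger inhibitor, a higher number a weaker inhibitor. Compound 2 has the lowest number of the three; compound 3 is nearest to it, within the scatter, while compound 1 sits furthest away, beyond the scatter. The two measured steps both start from compound 1: a 3.3-fold lower number from compound 1 to compound 2 (0.52 log units; beyond the scatter), and a 2.4-fold lower number from compound 1 to compound 3 (0.37 log units; beyond the scatter).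

The next compound, compound 4, `O=C(Nc1cccc(Cl)c1)Nc1cccc(CNc2nccnc2Cl)c1`, differs from compound 2 in one place: hydrogen in place of chloro on an aromatic carbon. The 3,4-dichlorophenyl becomes 3-chlorophenyl, so compound 4 stands between compound 1 and compound 2 in substitution. Among the measured compounds shown here, the only step that bears directly on it is the one from compound 1 to compound 2, which was modest; compound 4 keeps part of that change. The account therefore expects a rise in the number from compound 2 to compound 4, smaller than the whole step from compound 1 to compound 2, and quite possibly within the scatter. The estimate for compound 4 in this assay is 8000 nM, with a range from 4000 nM to 16000 nM, meaning an expected step of a 1.6-fold higher number from compound 2 to compound 4 (0.21 log units; within the scatter).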

Compound 4, half-maximal inhibitory concentration: 5330 nM
Compound 4: middle estimate off by 1.5-fold (0.18 log units), on the high side; low and high end bracket the measured number.
By their numbers in this assay, from the lowest: compounds 2, 4 and 3 (each within the scatter of the next); then compound 1.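

In this assay, hydrogen in place of chloro on this aromatic carbon, ortho to a chloro group and para to a large group, gives a 1.1-fold higher number from compound 2 to compound 4 (0.03 log units; within the scatter), so the chloro that leaves makes no difference that can be told from the scatter. The 3-chlorophenyl group keeps a clear gain over plain phenyl, with a 3.1-fold lower number from compound 1 to compound 4 (0.49 log units; beyond the scatter), which shows that one chloro is enough to give a step beyond the scatter and that the second chloro of the 3,4-dichlorophenyl group adds no separable gain in this pair. No supporting measurement bears on why this chloro can leave with so little effect on the reading.

The compounds shown leave open whether the remaining chloro must stand where it does in compound 4, since a 4-chlorophenyl group, with chloro only on the carbon that compound 4 leaves bare, is not among them. They also leave open whether that carbon accepts groups of another kind, such as a methoxy group, an amine or a carboxylic acid, as readily as it accepts hydrogen or chloro.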